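Compound 1 and a Larger Group on the Ring

The compounds below may be only part of what the source reports. "The series", "measured", "known", "first", "only" and "open" are said of these compounds alone.

In an ADME assay on cells (Erythrocyte, Homo sapiens), read by spectrophotometry and hemolysis, with a stated time of 24 h (a lower number here means a stronger inhibitor, a higher number a weaker inhibitor), compound 1 (`O=Cc1ccccc1OCc1ccc2no[n+]([O-])c2c1`) gives > 100 uM, which is a limit and not a number. Compound 2 (`CC1(C)[N+]([O-])=c2ccc(COc3cccc(C=O)c3)cc2=[N+]1[O-]`) gives < 50 uM, also a limit. Compound 1 therefore stands only at a limit, with no exact value. Compound 3 (`C=CCNC(=S)N/N=C\c1ccccc1OCc1ccc2no[n+]([O-])c2c1`) keeps the core of compound 1 but replaces the formyl on an aromatic carbon with a larger group that has no ring: a group of 9 heavy atoms (5 carbon, 3 nitrogen, 1 sulfur; no ring) in place of a group of 2 heavy atoms (1 carbon, 1 oxygen; no ring), on an aromatic carbon. Among the compounds with values here, no measured step between close relatives is available as a guide. The expected change is none beyond the usual scatter, an estimated a number no higher from compound 1 to compound 3 (the limit leaves the size open). For compound 3 the expected value is 100 uM, with an estimated range from 40 uM to 250 uM.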

Compound 3, concentration for 50% inhibition: 139 uM
The estimate for compound 3 lay 1.4-fold (0.14 log units) below the measured number, within the range that was stated.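

Compound 1 stands only at a limit, and the step from compound 1 to compound 3 cannot be read in size. The compounds shown leave open whether replacing the formyl with the larger group changes the number at all.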